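Compound 3: dropping the 4-methoxybenzyl group

A few compounds are considered here, and "the series" means these few. Any claim that something is new, unique, unknown or untested is made for them only; others in the source may bear on it.

Of the compounds shown here, two have numbers so far in a functional assay with Homo sapiens as the target, read by hemolysis; on this read-out lower numbers stand for stronger inhibition and higher numbers for weaker inhibition. Compound 1 `CC1(C)C2CCC[C@H](/C=C/c3ccc(C(=O)O)cc3)[C@@]2(C)CC[C@@H]1O` gives 623000 nM there, and compound 2 `COc1ccc(CO[C@H]2CC[C@]3(C)C[C@H](Cc4cccc(C(=O)O)c4)CCC3C2(C)C)cc1` gives 488000 nM on the same read-out. These two values lie within the scatter of each other, so compound 2 stands level with compound 1.

Compound 3 `CC1(C)C2CC[C@@H](Cc3cccc(C(=O)O)c3)C[C@@]2(C)CC[C@@H]1O` has not been measured yet. It departs from compound 2 by hydrogen in place of 4-methoxybenzyl on an oxygen on a saturated carbon, which reads as (4-methoxybenzyl)oxy to hydroxy.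

For the measured compounds named here, no measured pair isolates this change, so the expectation rests on indirect evidence only. Compound 1 also carries a hydroxy and gives 623000 nM on a different core arrangement, level with compound 2 and without any sign of a large shift. No step beyond the scatter is therefore expected in this assay, and any drift would most likely be slight and towards a higher number. The expected step of a 1.1-fold higher number from compound 2 to compound 3 (0.05 log units; within the scatter) is estimated to stay small. In this assay the estimate for compound 3 is 550000 nM with an expected range from 250000 nM to 1200000 nM as the likely span.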

Compound 3, half-maximal inhibitory concentration: 601000 nM
Beside the measured number, compound 3's estimate is 1.1-fold (0.04 log units) below it; low and high end bracket the measured number.
By their numbers in this assay, from the lowest: compounds 2, 3 and 1 (each within the scatter of the next).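

In this assay, for the compounds shown here, compounds 2 and 3 form the first pair that differs in one place, and going from (4-methoxybenzyl)oxy to hydroxy on the saturated carbon gives a 1.2-fold higher number from compound 2 to compound 3 (0.09 log units; within the scatter). At this position, the read-out therefore does not separate the full 4-methoxybenzyl group from hydrogen on the oxygen, so the aromatic ring and methoxy group of that substituent carry no visible weight in this pair. No supporting data bear on this result, and the pair alone gives no explanation for it.

Still open, as far as these compounds go, is whether a different group on this oxygen, such as a methyl ether, an acetate ester or a longer alkyl chain, or an amine in place of the hydroxy, would give a step beyond the scatter from compound 3. All three compounds carry a carboxylic acid, so the compounds shown also leave open how a primary amide or a tetrazole in its place would read, and whether any change to the shared core of compound 2 and compound 3 would move the number.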